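The source may hold more compounds than are shown below. What is called first, only, known or untested is meant among the compounds shown, and "the series" means these compounds.

Measured so far:
- compound 1 `O=[N+]([O-])c1cc(Cl)ccc1CNc1cc(C(F)(F)F)cc2[nH]ncc12`: 50%
- compound 2 `Cc1ccc(CNc2cc(C(F)(F)F)cc3[nH]ncc23)c([N+](=O)O)c1`: 36%

In an assay for inhibition of Indoleamine 2,3-dioxygenase 1 (Homo sapiens), with stated times of 10 min and 60 min, tested at 10 uM (on this read-out higher numbers stand for a stronger effect at the one concentration tested and lower numbers for a weaker effect), compound 1 gives 50%, the higher of the two numbers shown, and compound 2 gives 36%, a number far enough below it to lie beyond the usual scatter of this assay. Compound 3 `O=[N+]([O-])c1ccccc1CNc1cc(C(F)(F)F)cc2[nH]ncc12` is not yet measured. It differs from compound 1 in one place: hydrogen in place of chloro on an aromatic carbon. The chloro group leaves and nothing but a hydrogen atom takes its place on the aromatic ring of carbon only, so compound 3 is a smaller version of compound 1 with its other parts unchanged. Within the data shown here, no step between measured compounds is available to say what such a removal does here, so the expectation rests on compound 1 alone, whose value of 50% is the starting point. A modest drop is expected, a number 10 percentage points lower from compound 1 to compound 3 (within the scatter), though a change within the scatter cannot be ruled out. Compound 3 is therefore estimated at 40%, within a range from 22% to 58%.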

Compound 3, a percentage reported as inhibition, at one concentration (the size of the read-out at that concentration, not a potency): 35%
Beside the measured number, compound 3's estimate is 5 percentage points above it, within the range that was stated.
By their numbers in this assay, from the lowest: compounds 3 and 2 (each within the scatter of the next); then compound 1.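

In this assay, replacing the chloro group with a hydrogen atom on this aromatic carbon gives a number 15 percentage points lower from compound 1 to compound 3 (beyond the scatter) and so shows that this place, meta to the nitro group and para to the large group, is not indifferent to what sits on it. Among these compounds, this is the first single change that can be read directly here, and it shows that the chlorine atom counts for something in the size of the effect at the one concentration tested, though it gives no potency. No measurement at hand explains why the read-out falls with this change.

Going by these compounds, whether a fluorine atom, a methoxy group or a longer chain on this same aromatic carbon would match the chloro group or exceed it remains open. Also open, on these data alone, is what an amine or a carboxylic acid in place of the nitro group would do to the read-out.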